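Compound 3 to compound 4: a larger chlorine-bearing group

The source may report more compounds than this note shows. Statements on the series, on what has been measured and on what is new or still open speak of the compounds shown alone.

In a functional assay on A549 cells (Homo sapiens) for antiproliferative activity, read by MTT assay, with a stated time of 48 h (on this read-out higher numbers stand for weaker inhibition and lower numbers for stronger inhibition), compound 1 (`O=[N+]([O-])c1cc(C(F)(F)F)cc([N+](=O)[O-])c1Oc1ccccc1/C=N\OCc1ccccc1`) gives 1470 nM. Compound 2 (`O=[N+]([O-])c1cc(C(F)(F)F)cc([N+](=O)[O-])c1Oc1ccc(Cl)cc1/C=N\OCc1ccccc1`) gives 3410 nM, and compound 3 (`O=[N+]([O-])c1cc(C(F)(F)F)cc([N+](=O)[O-])c1Oc1c(Cl)cc(Cl)cc1/C=N\OCc1ccccc1`) gives 1450 nM. Compound 3 and compound 1 therefore lie within the usual scatter of each other, while compound 2 stands apart from both with the highest number of the three.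

Compound 4 (`O=[N+]([O-])c1cc(C(F)(F)F)cc([N+](=O)[O-])c1Oc1c(Cl)cc(Cl)cc1/C=N/OCc1ccc(Cl)cc1Cl`) has not yet been measured. Its difference from compound 3 is a group of 12 heavy atoms (8 carbon, 1 nitrogen, 1 oxygen, 2 chlorine; one six-membered aromatic ring of carbon only) in place of a group of 10 heavy atoms (8 carbon, 1 nitrogen, 1 oxygen; one six-membered aromatic ring of carbon only), on an aromatic carbon, and the change sits on an aromatic carbon ortho to a large group.

Two measured steps offer a partial guide, as both put chloro in place of hydrogen on an aromatic carbon. The first is a 2.3-fold higher number from compound 1 to compound 2 (0.37 log units; beyond the scatter), and the second is a 2.4-fold lower number from compound 2 to compound 3 (0.37 log units; beyond the scatter). Both are modest, and they run in opposite directions. Among the compounds with values here, neither involves the group that changes here, and no measured compound shows that exchange directly. Going by these compounds, the direction of any shift therefore stays open, so no step beyond the scatter is expected in this assay, although a modest one in either direction would not surprise.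

The expected step is a 1.1-fold lower number from compound 3 to compound 4 (0.05 log units; within the scatter). The estimate for compound 4 is 1300 nM, within an expected range of 450 nM to 3800 nM.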

Compound 4, half-maximal inhibitory concentration: 1420 nM
Compound 4: the middle estimate sits 1.1-fold (0.04 log units) below what was measured; measured number inside the range.
By their numbers in this assay, from the lowest: compounds 4, 3 and 1 (each within the scatter of the next); then compound 2.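

In this assay, the group of 12 heavy atoms, which carries chlorine, replaces the group of 10 heavy atoms with a 1.0-fold lower number from compound 3 to compound 4 (0.01 log units; within the scatter) and so leaves the read-out within the usual scatter. This shows that this place, an aromatic carbon ortho to a large group, tolerates the larger chlorine-bearing group without any change that this assay can distinguish, at least when the rest of compound 3 is kept. The earlier chloro exchanges each moved the number beyond the scatter, in opposite directions, so across these four compounds adding chlorine has no single outcome, and here it has no visible one, though no measurement shown explains this difference in behaviour.

A single exchange at this place says little about groups of another kind, and an amine or a carboxylic acid on the same ring could give a quite different number. The structures also draw the double bond in the entering group with the opposite geometry, and no compound shown separates that difference from the added chlorine.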